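This account rests on a few compounds, and the source may have more. Where it says the series, first, only, none or still open, it means among the compounds named here.

Measured in a functional assay on the whole organism (strain Sprague-Dawley) for inhibition, with Rattus norvegicus as the target; a lower number here means that less compound is needed, a higher number that more compound is needed for the effect:
compound 1, `COc1cccc2cc(-c3nn[nH]n3)cnc12`, gives 2.5 mg/kg.
compound 2, `FC(F)(F)c1cccc2cc(-c3nn[nH]n3)cnc12`, gives only a limit, < 25 mg/kg.
compound 3, `c1ccc2ncc(-c3nn[nH]n3)cc2c1`, gives 10 mg/kg.

Compound 3 holds the highest of the two readable numbers; its nearest neighbour is compound 1, reached by a 4.0-fold higher number from compound 1 to compound 3 (0.60 log units; beyond the scatter), a step beyond the scatter. Compound 2 sets only a limit, so the pair of compound 2 and compound 3 shows nothing readable about their difference: a step that the limit leaves unreadable from compound 2 to compound 3.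

Going by the values given here, compound 4, `Cc1cccc2cc(-c3nn[nH]n3)cnc12`, is not yet measured. methyl in place of hydrogen on an aromatic carbon The only readable step at this position is a 4.0-fold higher number from compound 1 to compound 3 (0.60 log units; beyond the scatter), where hydrogen in place of methoxy gives a higher number. The step from trifluoromethyl to hydrogen is left unreadable by the limit of < 25 mg/kg in this assay, at which 1 of the 3 values shown sits. Among the compounds with values here, no measured pair shows whether methyl behaves like methoxy at this position. Given a 4.0-fold higher number from compound 1 to compound 3 (0.60 log units; beyond the scatter), compound 4 is expected to land between the two readable numbers, with an expected step of a 2.5-fold lower number from compound 3 to compound 4 (0.40 log units; beyond the scatter). The estimate for compound 4 in this assay is 4 mg/kg, with a range from 1.5 mg/kg to 12 mg/kg.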

Compound 4, minimum effective dose: < 25 mg/kg
Compound 4 gave a limit, no number; the forecaster's own chance of this, stated with the estimate: 10%; the middle value does not contradict the limit.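

In this assay compound 4 gives only a limit, < 25 mg/kg. Going by these compounds alone, no step linking compound 4 with compound 1, compound 2 or compound 3 can be read: the limit of < 25 mg/kg in this assay, at which 2 of the 4 values shown sit. The compounds shown leave open whether methyl gives a number closer to that of compound 1 or that of compound 3.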